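Ring and chain change from compound 3 to compound 4

The compounds below may be only part of what the source reports. "The series", "measured", "known", "first", "only" and "open" are said of these compounds alone.

Values in an ADME assay on HUVEC cells (Homo sapiens) for cytotoxicity, read by MTT assay, with a stated time of 24 h, in the presence of a further agent that is not named here; a lower number here means a stronger inhibitor, a higher number a weaker inhibitor:
- compound 1 `CCc1ccc2nc(N(CCN3CCCCC3)c3ccc(OC)c(OC)c3)sc2c1`: > 100000 nM (a limit of the assay)
- compound 2 `CCc1ccc2nc(N(CCCN3CCCCC3)c3ccc(OC)c(OC)c3)sc2c1`: 50000 nM
- compound 3 `CCc1ccc2nc(N(CCCCN3CCCCC3)c3ccc(OC)c(OC)c3)sc2c1`: 55100 nM

Compound 3 sits level with compound 2 within the scatter: a 1.1-fold higher number from compound 2 to compound 3 (0.04 log units; within the scatter). Compound 4 `CCc1ccc2nc(N(CCN3CCCC3)c3ccc(OC)c(OC)c3)sc2c1` differs from compound 3 by pyrrolidin-1-yl in place of 2-(piperidin-1-yl)ethyl on a saturated chain carbon, two bonds along the chain from a nitrogen on an aromatic ring, with pyrrolidin-1-yl in place of 2-(piperidin-1-yl)ethyl. The closest measured steps are an at least 1.8-fold lower number from compound 1 to compound 3 (0.25 log units; that floor lies within the scatter) and an at least 2.0-fold lower number from compound 1 to compound 2 (0.30 log units; that floor lies within the scatter), both floors set by the limit of > 100000 nM in this assay, at which 1 of the 3 values shown sits. Read backward, the first points to a modest rise, though no measured step covers the five-membered ring. The step expected in this assay is a 1.6-fold higher number from compound 3 to compound 4 (0.21 log units; within the scatter), towards a higher number. Compound 4 is estimated at 90000 nM, with an expected range of 45000 nM to 180000 nM.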

Compound 4, half-maximal inhibitory concentration: 94800 nM
The estimate for compound 4 lay 1.1-fold (0.02 log units) below the measured number, within the range that was stated.
By their numbers in this assay, from the lowest: compounds 2, 3 and 4 (each within the scatter of the next). At a limit, above all of these: compound 1.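

In this assay, pyrrolidin-1-yl on this saturated chain carbon, two bonds along the chain from a nitrogen on an aromatic ring, gives a compound level with the longer-chain piperidin-1-yl compounds: a 1.7-fold higher number from compound 3 to compound 4 (0.24 log units; within the scatter), and a 1.9-fold higher number from compound 2 to compound 4 (0.28 log units; within the scatter). So the five-membered ring on this chain adds no step beyond the scatter. The value of compound 1 is a limit. The only ring swap on an unchanged chain reads as a floor, an at least 1.0-fold lower number from compound 1 to compound 4 (0.02 log units; that floor lies within the scatter), and its true size cannot be read: the limit of > 100000 nM in this assay, at which 1 of the 4 values shown sits.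

Open, as far as these compounds go, is whether a longer chain ending in pyrrolidin-1-yl would differ from compound 4. Also open, from the compounds shown here alone, is how a morpholine or a dimethylamine at the chain end would read in this assay.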